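Phenylsulfonyl replacing methylsulfonyl on an indole-type sulfonamide

This account rests on a few compounds, and the source may have more. Where it says the series, first, only, none or still open, it means among the compounds named here.

Measured compounds:
compound 1, `Cc1ccc(S(=O)(=O)N(Cc2cn(Cc3cccc(F)c3F)nn2)Cc2cn(S(=O)(=O)c3ccc(C)cc3)c3ccccc23)cc1`, 71.5%
compound 2, `Cc1ccc(S(=O)(=O)N(Cc2cn(Cc3cc(F)ccc3F)nn2)Cc2cn(S(C)(=O)=O)c3ccccc23)cc1`, 3.4%

In a functional assay on 3T3-L1 cells (Mus musculus) for inhibition, with a stated time of 20 min, tested at 20 uM (on this read-out higher numbers stand for more inhibition at the one concentration tested (going by the name of the read-out) and lower numbers for less inhibition), compound 1 gives 71.5%, while compound 2 gives 3.4%, the lowest of the two numbers and far beyond the usual scatter from compound 1. Compound 3, `Cc1ccc(S(=O)(=O)N(Cc2cn(Cc3cc(F)ccc3F)nn2)Cc2cn(S(=O)(=O)c3ccccc3)c3ccccc23)cc1`, is not yet measured. It differs from compound 2 in one place: phenyl in place of methyl on a sulfonyl sulfur. For the measured compounds named here, since no measured pair shows this exact change, the expected step is uncertain, but an increase is expected, a number 41.6 percentage points higher from compound 2 to compound 3 (beyond the scatter). Compound 3 is therefore estimated at 45%, with a range from 10% to 80%.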

Compound 3, a percentage reported as inhibition, at one concentration (the size of the read-out at that concentration, not a potency): -6.5%
The estimate for compound 3 lay 51.5 percentage points above the measured number; measured number outside the range, below it.
By their numbers in this assay, from the lowest: compounds 3 and 2 (each within the scatter of the next); then compound 1.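

In this assay, phenyl in place of methyl on a sulfonyl sulfur gives a number 9.9 percentage points lower from compound 2 to compound 3 (within the scatter) and so brings no measurable gain in inhibition. A phenyl ring on this sulfur is therefore not enough by itself to produce the high number of compound 1. Nothing available here explains this result. As far as these compounds go, compound 1 differs from compound 3 in more than one place, so it remains open which of those differences goes with its higher number. Also open, from the compounds shown here alone, is how an ethyl group or an amine-bearing chain would read on this sulfur.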